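Estimating compound 3 from two closely matched neighbours

The compounds below may be only part of what the source reports. "The series", "measured", "known", "first", "only" and "open" are said of these compounds alone.

- compound 1 `COc1ccc(/C=N\NC(=S)NC(C)(C)CCC[C@](C)(O)[C@@H]2CC=C(C)CC2)cc1` gives 46200 nM
- compound 2 `CC1=CC[C@@H]([C@@](C)(O)CCCC(C)(C)NC(=S)N/N=C\c2ccccc2[N+](=O)[O-])CC1` gives 41900 nM

Among the measured compounds shown here, in a functional assay on OVCAR-3 cells (Homo sapiens) for cytotoxicity, read by sulforhodamine B assay (on this read-out higher numbers stand for lower toxicity in this test and lower numbers for higher toxicity in this test), compound 1 stands level with compound 2, the only other measured compound, as their two values lie within the scatter. Compound 3 `CC1=CC[C@@H]([C@@](C)(O)CCCC(C)(C)NC(=S)N/N=C(/C)c2ccccc2)CC1` differs from compound 1 in one place, with a group of 9 heavy atoms (8 carbon, 1 nitrogen; one six-membered aromatic ring of carbon only) in place of a group of 10 heavy atoms (8 carbon, 1 nitrogen, 1 oxygen; one six-membered aromatic ring of carbon only), on an amide-type nitrogen as the change. For the measured compounds named here, the one measured step that bears on this is a 1.1-fold lower number from compound 1 to compound 2 (0.04 log units; within the scatter) and it put 2-nitrophenyl in place of 4-methoxyphenyl inside the group that leaves here. Going by the values given here, that step stayed within the scatter, but no measured compound carries the entering group, so the evidence is thin. No step beyond the scatter is therefore expected in this assay in either direction. The expected size of the change is a 1.1-fold lower number from compound 1 to compound 3 (0.04 log units; within the scatter) as an estimate only. For compound 3 the estimated value is 42000 nM with an expected range of 20000 nM to 85000 nM around it.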

Compound 3, concentration lethal to 50% of the cells: > 100000 nM
Compound 3: a limit, no number (the forecaster's own chance of this, stated with the estimate: 5%); at least 2.3-fold (0.37 log units) between middle value and limit.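

Compound 1 and compound 2 suggested that the group on this amide-type nitrogen could be exchanged with little effect in this assay, as their step was a 1.1-fold lower number from compound 1 to compound 2 (0.04 log units; within the scatter). The group of 9 heavy atoms changes that picture, giving an at least 2.1-fold higher number from compound 1 to compound 3 (0.33 log units; beyond the scatter), so this place can show a real shift toward lower toxicity in this test. The reading for compound 3 is a limit of the assay and not a number: the limit of > 100000 nM in this assay, at which 1 of the 3 values shown sits.

The true size of the step therefore stays open, and so does the question of which feature of the entering group accounts for it, as the group differs from the one it replaces in more than its missing oxygen. Going by these compounds, it also remains open how a group carrying a pyridine ring or a carboxylic acid would behave on this nitrogen.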